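A few compounds are considered here, and "the series" means these few. Any claim that something is new, unique, unknown or untested is made for them only; others in the source may bear on it.

Four compounds built on one shared core were examined in a functional assay on mitochondria from heart for inhibition of peroxisomal acyl-coenzyme A oxidase 1 (Rattus norvegicus); a higher number here means a weaker inhibitor, a lower number a stronger inhibitor. Compound 1 `Cc1nc2cc(OC[C@H](O)CN3CCN(Cc4noc(-c5ccc(C(C)(C)C)cc5)n4)CC3)ccc2s1` gives 180 nM. Compound 2 `Cc1nc2cc(OC[C@H](O)CN3CCN(Cc4noc(-c5ccc(Cl)cc5)n4)CC3)ccc2s1`, which carries chloro in place of tert-butyl on an aromatic carbon, gives 2270 nM; this is a 13-fold higher number from compound 1 to compound 2 (1.10 log units; beyond the scatter). Compound 3 `Cc1nc2cc(OC[C@H](O)CN3CCN(Cc4nnc(-c5ccc(C(C)(C)C)cc5)o4)CC3)ccc2s1` has the same atoms as compound 1 joined differently; the difference between the two cores is not broken down here. In this assay compound 3 gives 1100 nM, between the other two values. Compound 4 `Cc1nc2cc(OC[C@H](O)CN3CCN(Cc4nnc(-c5ccc(Cl)cc5)o4)CC3)ccc2s1` differs from compound 3 by chloro in place of tert-butyl on an aromatic carbon, the same change made from compound 1 to compound 2, at the same place. Given a 13-fold higher number from compound 1 to compound 2 (1.10 log units; beyond the scatter), a weakening of similar size is expected for compound 4, estimated as a 9.1-fold higher number from compound 3 to compound 4 (0.96 log units; beyond the scatter). Compound 4 is therefore expected to give about 10000 nM, within a range from 3500 nM to 30000 nM.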

Compound 4, half-maximal inhibitory concentration: 8500 nM
Beside the measured number, compound 4's estimate is 1.2-fold (0.07 log units) above it; low and high end bracket the measured number.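

In this assay, chloro in place of tert-butyl on an aromatic carbon again weakens inhibition on the second core, giving a 7.7-fold higher number from compound 3 to compound 4 (0.89 log units; beyond the scatter). Set beside the earlier step, the change carries from one core to the other with no size difference that can be told apart: the same change on two cores in this assay, a 13-fold higher number (1.10 log units; beyond the scatter) from compound 1 to compound 2 and a 7.7-fold higher number (0.89 log units; beyond the scatter) from compound 3 to compound 4, 1.6-fold (0.21 log units) apart, within the scatter of two such steps. This shows agreement for one pair of groups on two cores in one assay; it does not show that the step would hold on any further core, nor does it explain why the number moves.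

The compounds shown leave open how other groups would read at this place, such as methoxy, trifluoromethyl or an amine. On these data alone, whether these would also track across both cores remains unknown.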